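Ester Swap on a Shared Core: Expecting Weak Cytotoxicity

The compounds below may be only part of what the source reports. "The series", "measured", "known", "first", "only" and "open" are said of these compounds alone.

compound 1 `C/C=C(/C)C(=O)O[C@@H]1C/C=C(\C)CCCC(C)(C)[C@@H](O)/C=C\1C`: "not active" (no number reported)
compound 2 `C/C1=C/[C@H](O)C(C)(C)CCC/C(C)=C/C[C@H]1OC(=O)c1ccccc1`: "not active" (no number reported)
compound 3 `CC(=O)O[C@H]1/C=C(/C)[C@H](OC(=O)c2ccc(O)cc2)C/C=C(\C)CCCC1(C)C`: 33000 nM

In a functional assay on K562 cells (Homo sapiens) for cytotoxicity, read by MTT assay (on this read-out higher numbers stand for weaker inhibition and lower numbers for stronger inhibition), compound 1 gives "not active" (no number reported), so no number is reported for it, and compound 2 likewise gives "not active" (no number reported). Among the measured compounds shown here, compound 3 gives 33000 nM in this assay, the only number in the set. Compound 1 therefore stands among the compounds without a measurable value. Compound 4 `COc1cc(C(=O)O[C@@H]2C/C=C(\C)CCCC(C)(C)[C@@H](O)/C=C\2C)ccc1O` arises from compound 1 through the change (4-hydroxy-3-methoxyphenyl in place of 1-methylprop-1-en-1-yl on a carbonyl carbon). For the measured compounds named here, no measured pair shows this step, so its size is open; compound 3, the one numbered compound, also carries an ester with an aromatic ring and is weak. In this assay compound 4 is expected to move at most from "not active" to a weak, barely measurable value. Compound 4 is estimated at 40000 nM, within 10000 nM to 150000 nM, with a real chance that again only an inactive call is reported.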

Compound 4, half-maximal inhibitory concentration: > 50000 nM
Compound 4: only a limit was reported; the forecaster's own chance of this, stated with the estimate: 55%; middle value at least 1.2-fold (0.09 log units) away from the limit.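

Compound 4 gives only a limit, > 50000 nM, and compound 1 has no number, so no step can be read between them. Going by these compounds, whether exchanging 1-methylprop-1-en-1-yl for 4-hydroxy-3-methoxyphenyl changes cytotoxicity at all stays open.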